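A few compounds are considered here, and "the series" means these few. Any claim that something is new, unique, unknown or untested is made for them only; others in the source may bear on it.

Of the compounds shown here, three sharing one core have been tested in a functional assay on the whole organism for inhibition, with Rattus norvegicus as the target, read by paw edema, at a dose of 100 mg/kg by the oral route; on this read-out higher numbers stand for more inhibition at the one dose given (going by the name of the read-out) and lower numbers for less inhibition. Compound 1, `O=C(Nc1ccccn1)c1c(O)c2cccnc2n(-c2ccccc2)c1=O`, gives -13.5% in this assay. Compound 2, `O=C(Nc1ccccc1)c1c(O)c2cccnc2n(-c2ccccc2)c1=O`, gives 4.6%, a step of a number 18.1 percentage points higher from compound 1 to compound 2 (beyond the scatter). Compound 3, `O=C(Nc1ccc([N+](=O)[O-])cc1)c1c(O)c2cccnc2n(-c2ccccc2)c1=O`, gives -7.6%; it stands second highest of the three, nearest to compound 1 through the step of a number 5.9 percentage points higher from compound 1 to compound 3 (within the scatter), and furthest from compound 2 through the step of a number 12.2 percentage points lower from compound 2 to compound 3 (beyond the scatter).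

Compound 4, `COc1cccc(NC(=O)c2c(O)c3cccnc3n(-c3ccccc3)c2=O)c1`, has not yet been measured in this assay. It differs from compound 3 in one place: 3-methoxyphenyl in place of 4-nitrophenyl on an amide-type nitrogen. The step that bears most on this change is a number 12.2 percentage points lower from compound 2 to compound 3 (beyond the scatter), which shows what adding the nitro group did; taking it away again should undo roughly that much. Nothing measured shows what a methoxy group on this ring does, so the rest is uncertain. Compound 4 is therefore expected to lie near compound 2, a step of a number 10.6 percentage points higher from compound 3 to compound 4 (beyond the scatter), with an estimate for compound 4 of 3% and a range from -14% to 20%.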

Compound 4, a percentage reported as inhibition, in the whole organism at one dose (the size of the read-out at that dose, not a potency): 5.7%
For compound 4 the middle estimate is 2.7 percentage points below the measured one; low and high end bracket the measured number.
By their numbers in this assay, from the lowest: compounds 1 and 3 (each within the scatter of the next); then compounds 2 and 4 (each within the scatter of the next).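

At this amide-type nitrogen, a substituent on the phenyl ring does not always lower the number in this assay: the nitro group did, but methoxy in place of hydrogen gives a number 1.1 percentage points higher from compound 2 to compound 4 (within the scatter). The 3-methoxyphenyl group therefore falls alongside plain phenyl, with a number 13.3 percentage points higher from compound 3 to compound 4 (beyond the scatter) and a number 19.2 percentage points higher from compound 1 to compound 4 (beyond the scatter), so the series now splits into two pairs: compounds 2 and 4 on the higher side, and compounds 1 and 3 on the lower. No available evidence explains why these groups differ.

The compounds shown leave open whether methoxy would read the same as a 4-methoxyphenyl group, since only one placement of it appears here. They also leave open whether an amine or a carboxylic acid on this ring, or a longer chain in place of the ring, would rise beyond the scatter of compound 2.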